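This account rests on a few compounds, and the source may have more. Where it says the series, first, only, none or still open, it means among the compounds named here.

Compound 1 `Cc1cccc(-n2cc(-c3ccc(/C=C4\C(=O)Nc5ccccc54)cc3)nn2)c1`: 13700 nM
Compound 2 `O=C1Nc2ccccc2/C1=C/c1ccc(-c2cn(-c3ccc(Cl)cc3)nn2)cc1`: 18200 nM
Compound 3 `N#Cc1ccccc1-n1cc(-c2ccc(/C=C3\C(=O)Nc4ccccc43)cc2)nn1`: 19700 nM

In an ADME assay on HUVEC cells (Homo sapiens) for inhibition, read by CCK-8 assay, with a stated time of 24 h, in the presence of a further agent that is not named here (a higher number here means a weaker inhibitor, a lower number a stronger inhibitor), compound 3 gives 19700 nM and stands level with the other two compounds. Its gaps to them, a 1.1-fold higher number from compound 2 to compound 3 (0.03 log units; within the scatter) and a 1.4-fold higher number from compound 1 to compound 3 (0.16 log units; within the scatter), both lie within the usual scatter of repeated measurements.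

Compound 4 `N#Cc1cccc(-n2cc(-c3ccc(/C=C4\C(=O)Nc5ccccc54)cc3)nn2)c1` has the same atoms as compound 3, joined differently (3-cyanophenyl in place of 2-cyanophenyl on an aromatic nitrogen). The change is 3-cyanophenyl in place of 2-cyanophenyl on an aromatic nitrogen, so the nitrile stays and only its place on the phenyl ring differs. This exact swap has not been measured in any pair here. The closest evidence comes from the other changes of the group at this same place. Alongside the two steps above, there is a 1.3-fold higher number from compound 1 to compound 2 (0.12 log units; within the scatter) and it too stays within the scatter. Three different groups have therefore given values level with one another, and nothing here suggests that this swap should behave differently. The expected change is small, a 1.2-fold lower number from compound 3 to compound 4 (0.09 log units; within the scatter) and so none beyond the scatter, with no firm direction. For compound 4 the estimate is 16000 nM with an expected range from 9000 nM to 28000 nM in this assay.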

Compound 4, half-maximal inhibitory concentration: > 20000 nM
Compound 4: a limit, no number; the forecaster's own chance of this, stated with the estimate: 5%; middle value at least 1.2-fold (0.09 log units) away from the limit.
By their numbers in this assay, from the lowest: compounds 1, 2 and 3 (each within the scatter of the next). At a limit, above all of these: compound 4.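

In this assay compound 4 gives > 20000 nM, which is a limit of the assay and not a number. The steps to it can therefore be read only as floors, an at least 1.0-fold higher number from compound 3 to compound 4 (0.00 log units; that floor lies within the scatter), an at least 1.0-fold higher number from compound 2 to compound 4 (0.04 log units; that floor lies within the scatter) and an at least 1.4-fold higher number from compound 1 to compound 4 (0.16 log units; that floor lies within the scatter), and each of these floors lies within the scatter, so none shows a real difference, although none rules one out either. Among the compounds shown here, until now, every group on this aromatic nitrogen had given a number level with the others, so the swap from 2-cyanophenyl to 3-cyanophenyl is the first change here whose size stays unknown, and the new information at this place rests on a single compound: the limit of > 20000 nM in this assay, at which 1 of the 4 values shown sits.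

The compounds shown leave open how far compound 4 truly lies from the other three, and so whether moving the nitrile around the phenyl ring matters at all in this assay. They also leave open what an amine or a carboxylic acid on this phenyl ring, in place of the nitrile, would give in this assay.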